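Adding a fluoro group to compound 2

This account rests on a few compounds, and the source may have more. Where it says the series, first, only, none or still open, it means among the compounds named here.

Measured so far in an ADME assay on the whole organism (Rattus norvegicus, strain Sprague-Dawley) for pharmacokinetics, using cassette dosing, at a dose of 1 mg/kg by the oral route; on this read-out lower numbers stand for lower oral bioavailability and higher numbers for higher oral bioavailability:
Compound 1 `O=C(c1cc(-c2ccc(=O)[nH]c2)on1)N1CCC(Cc2ccc(Cl)cc2)CC1`: 9.3%
Compound 2 `O=C(Nc1ccc2[nH]c(=O)oc2c1)C(=O)N1CCN(c2ccc(Cl)cc2)CC1`: 17.8%

Only these two compounds have been measured in this assay. Compound 2, at 17.8%, lies within the usual scatter of compound 1, at 9.3%, so the two numbers cannot be told apart.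

The next compound, compound 3 `O=C(Nc1ccc2[nH]c(=O)oc2c1)C(=O)N1CCN(c2ccc(Cl)c(F)c2)CC1`, differs from compound 2 at a single place: fluoro in place of hydrogen on an aromatic carbon. This puts fluoro in place of hydrogen on an aromatic carbon, ortho to a chloro group and meta to a large group, turning 4-chlorophenyl into 4-chloro-3-fluorophenyl.

Among the compounds with values here, the two measured compounds differ in more than one place, so the data hold no direct precedent for this change. No step beyond the scatter is therefore expected in either direction, and the estimate stays close to compound 2 at 17.8%. The expected a number 1.2 percentage points higher from compound 2 to compound 3 (within the scatter) is small. Compound 3 is estimated at 19%, with an expected range from 7% to 36%.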

Compound 3, oral bioavailability: 28.2%
Compound 3: middle estimate off by 9.2 percentage points, on the low side; measured number inside the range.
By their numbers in this assay, from the lowest: compounds 1 and 2 (each within the scatter of the next); then compound 3.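

Within the data shown here, this is the first change in the set that can be read on its own, since compounds 1 and 2 differ in more than one place. In this assay, turning 4-chlorophenyl into 4-chloro-3-fluorophenyl gives a number 10.4 percentage points higher from compound 2 to compound 3 (beyond the scatter), so this single fluoro in place of hydrogen on an aromatic carbon, ortho to a chloro group and meta to a large group, moves the read-out by more than repeated measurements would. It is a single pair, however, and nothing in the data explains the rise, which shows only that this position on the ring can change oral bioavailability in the rat and gives no reason for it.

The compounds shown leave open whether the rise belongs to fluoro itself or would also follow from another group at the same place, such as a methyl, a methoxy, a nitrile or a second chloro. They also leave open whether the same fluoro would give a similar step on compound 1, whose core differs from that of compound 2.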